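This account rests on a few compounds, and the source may have more. Where it says the series, first, only, none or still open, it means among the compounds named here.

Measured so far:
Compound 1 `Cn1c(-c2ccc(F)cc2)nc2c(NC3CCCC3)ncnc21`, 1140 nM.
Compound 2 `CCn1c(-c2ccccc2)nc2c(NC3CCC3)ncnc21`, 84 nM.

In an assay on CHO cells for displacement of a labelled ligand from adenosine receptor A3 (Homo sapiens), read by scintillation counting, with a stated time of 3 h (on this read-out lower numbers stand for stronger inhibition and higher numbers for weaker inhibition), compound 1 gives 1140 nM, the higher of the two numbers recorded, so the weaker binder of the pair. Compound 2, the nearest comparison, sits at 84 nM, a gap well beyond the usual scatter, but the two differ in several places at once, so no single cause can be read from it.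

Compound 3 `Cn1c(-c2cccnc2)nc2c(NC3CCCC3)ncnc21` differs from compound 1 in one place: pyridin-3-yl in place of 4-fluorophenyl on an aromatic carbon. Among the measured compounds shown here, no measured pair shows this exact exchange. With nothing to go on, the expected step of a 1.1-fold higher number from compound 1 to compound 3 (0.02 log units; within the scatter) is small, not beyond the scatter in either direction. Compound 3 is therefore estimated at 1200 nM, with a likely range from 400 nM to 3600 nM.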

Compound 3, inhibition constant: 11000 nM
Compound 3: the middle estimate sits 9.2-fold (0.96 log units) below what was measured; measured number above the stated range.
By their numbers in this assay, from the lowest: compound 2; then compound 1; then compound 3.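

In this assay the group on this aromatic carbon clearly matters: pyridin-3-yl in place of 4-fluorophenyl gives a 9.6-fold higher number from compound 1 to compound 3 (0.98 log units; beyond the scatter) and is the first change shown in one place only. At this position, then, one six-membered aromatic ring cannot simply stand in for another. No measurement at hand explains this step.

The exchange adds a ring nitrogen and removes the fluorine together, and the compounds shown do not separate these two changes. Plain phenyl on the core of compound 1 could separate them, while pyridin-4-yl would test where the ring nitrogen sits.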